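The source may hold more compounds than are shown below. What is called first, only, known or untested is meant among the compounds shown, and "the series" means these compounds.

For the measured compounds named here, compound 3, with the structure `CC1=CC[C@@H]([C@@](C)(O)CCCC(C)(C)NC(=S)N/N=C\c2cccc(Cl)c2)CC1`, holds the only outright number among the three measured compounds: in a functional assay on K562 cells (Homo sapiens) for cytotoxicity, read by sulforhodamine B assay (on this read-out higher numbers stand for lower toxicity in this test and lower numbers for higher toxicity in this test), compound 3 gives 56300 nM. Compound 1, with the structure `CC1=CC[C@@H]([C@@](C)(O)CCCC(C)(C)NC(=S)N/N=C\c2ccccc2)CC1`, reaches only a limit of the assay, and in this assay compound 1 gives > 100000 nM. Compound 2, with the structure `COc1ccc(/C=N\NC(=S)NC(C)(C)CCC[C@](C)(O)[C@@H]2CC=C(C)CC2)cc1`, likewise reaches only a limit, and in this assay compound 2 gives > 100000 nM. The two limits rest on (the limit of > 100000 nM in this assay, at which 2 of the 3 values shown sit), so the step that the two limits leave unreadable from compound 1 to compound 2 cannot be read. The steps of an at least 1.7-fold lower number from compound 1 to compound 3 (0.24 log units; that floor lies within the scatter) and an at least 1.7-fold lower number from compound 2 to compound 3 (0.24 log units; that floor lies within the scatter) are both only floors, and each floor lies within the scatter.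

Compound 4, with the structure `CC1=CC[C@@H]([C@@](C)(O)CCCC(C)(C)NC(=S)N/N=C(/C)c2ccccc2)CC1`, differs from compound 3 by a group of 9 heavy atoms (8 carbon, 1 nitrogen; one six-membered aromatic ring of carbon only) in place of a group of 9 heavy atoms (7 carbon, 1 nitrogen, 1 chlorine; one six-membered aromatic ring of carbon only), on an amide-type nitrogen. Compound 1 is the nearest measured neighbour of compound 4: the chloro that compound 1 lacks and compound 3 carries is absent from compound 4 as well, and the step of an at least 1.7-fold lower number from compound 1 to compound 3 (0.24 log units; that floor lies within the scatter) shows that removing it points towards the limit rather than away from it. The account therefore expects compound 4 to move back towards the limit in this assay, by a step of a 1.8-fold higher number from compound 3 to compound 4 (0.25 log units; within the scatter). The estimate for compound 4 in this assay is 100000 nM, in a range from 40000 nM to 300000 nM, with a fair chance that only a limit is reported.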

Compound 4, concentration lethal to 50% of the cells: 1540 nM
Compound 4: the middle estimate sits 65-fold (1.81 log units) above what was measured; measured number outside the range, below it.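

In this assay, for the compounds shown here, the group on the amide-type nitrogen proves to be a place where a single change gives a large step, which the earlier comparisons could not show because their floors lay within the scatter: the entering group, with 8 carbon against 7 in the group it replaces, gives an at least 64-fold lower number from compound 1 to compound 4 (1.81 log units; beyond the scatter). The same place gives an at least 64-fold lower number from compound 2 to compound 4 (1.81 log units; beyond the scatter) and a 37-fold lower number from compound 3 to compound 4 (1.56 log units; beyond the scatter), so compound 4 is the most toxic of the compounds shown in this test, with its steps to all the others beyond the scatter, and the chloro of compound 3 does not match this change. The steps from compound 1 and compound 2 give only the least possible size, not the full one, because both compounds stay at a limit: the limit of > 100000 nM in this assay, at which 2 of the 4 values shown sit.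

The compounds shown leave open whether the lower number survives when the entering group also carries a chloro or methoxy on its aromatic ring. They also leave open whether a longer chain, such as an ethyl group, or an amine in that group would keep, deepen or lose the step.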